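The source may report more compounds than this note shows. Statements on the series, on what has been measured and on what is new or still open speak of the compounds shown alone.

Working notes on the series. In an ADME assay on liver for metabolic stability, with Liver microsome (Rattus norvegicus) as the target, read by LC-MS, using microsomes, with a stated time of 5 h (on this read-out lower numbers stand for slow clearance and higher numbers for fast clearance), compound 1 `O[C@H](c1ccccn1)[C@]1(c2ccc(C(F)(F)F)cc2)C[C@@H](O)C1` gives 50 mL/min/kg. Among the measured compounds shown here, only one other compound has a number so far: compound 2 `C[C@]1(O)C[C@](c2ccnc(C(F)(F)F)c2)([C@H](O)c2ccccn2)C1` gives 83.3 mL/min/kg in this assay. These two values lie within the usual scatter of each other, so compound 1 cannot be separated from compound 2 on these data.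

The next compound to consider is compound 3 `C[C@]1(O)C[C@@](c2ccc(C(F)(F)F)cc2)([C@H](O)c2ccccn2)C1`, which is compound 1 with methyl in place of hydrogen on a saturated ring carbon. For the measured compounds named here, no measured pair isolates this change, so there is no direct precedent for its size or direction. The expectation therefore starts from compound 1 at 50 mL/min/kg, and the range is kept wide.

No shift beyond the scatter is expected in this assay. The estimated step of a 1.1-fold higher number from compound 1 to compound 3 (0.04 log units; within the scatter) is small and has no firm direction. For compound 3, the estimated clearance is 55 mL/min/kg, with an expected range of 30 mL/min/kg to 95 mL/min/kg.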

Compound 3, clearance: 150 mL/min/kg
Estimate against measurement, compound 3: 2.7-fold (0.44 log units) below; measured number above the stated range.
By their numbers in this assay, from the lowest: compounds 1, 2 and 3 (each within the scatter of the next, the first and the last beyond it).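

Among the compounds shown here, the pair compound 1 and compound 3 is the first to isolate methyl in place of hydrogen on a saturated ring carbon, and in this assay this change gives a 3.0-fold higher number from compound 1 to compound 3 (0.48 log units; beyond the scatter) for the one swap. This shows that the position, on a four-membered non-aromatic ring of carbon only and two ring bonds from the ring atom that bears the hydroxy(pyridin-2-yl)methyl group, is not silent: a single added carbon, with no hydrogen-bond donor or acceptor among the atoms entering, is enough to raise the clearance number beyond the scatter. Nothing measured on these compounds speaks to what lies behind the step, which therefore stands as an observation only.

Whether an ethyl group, a fluorine atom or an amine at this carbon would take the clearance number further up or bring it back remains open, as the compounds shown carry only hydrogen or methyl there. A single pair also leaves open whether the step would recur on another core, and whether a methoxy group in place of the hydroxy group on this carbon would change it.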